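The source may report more compounds than this note shows. Statements on the series, on what has been measured and on what is new or still open speak of the compounds shown alone.

In a functional assay on the whole organism (strain C57BL/6) for inhibition, with Mus musculus as the target, read by paw edema, with stated times of 1 h and 4 h, at a dose of 100 mg/kg by the oral route (on this read-out lower numbers stand for less inhibition and higher numbers for more inhibition at the one dose given (going by the name of the read-out)), compound 3 `CC(=O)Nc1ccc(Cc2noc(CCC(=O)Nc3ccc(C(F)(F)F)cc3)n2)cc1` gives 37%, the second highest of three numbers. Compound 1 `CC(=O)Nc1ccc(Cc2noc(CCC(=O)Nc3ccccc3)n2)cc1` gives 34.2%, within the scatter of compound 3, while compound 2 `CC(=O)Nc1ccc(Cc2noc(CCC(=O)Nc3ccc(F)cc3)n2)cc1` gives 64.4%, the highest of the three. Compound 4 `C#Cc1cccc(NC(=O)CCc2nc(Cc3ccc(NC(C)=O)cc3)no2)c1` differs from compound 3 by 3-ethynylphenyl in place of 4-(trifluoromethyl)phenyl on an amide-type nitrogen. The measured steps at this same amide-type nitrogen bear on it: a number 30.2 percentage points higher from compound 1 to compound 2 (beyond the scatter), a number 2.8 percentage points higher from compound 1 to compound 3 (within the scatter) and a number 27.4 percentage points lower from compound 2 to compound 3 (beyond the scatter), so one change here moved the number beyond the scatter and another did not. Within the data shown here, no measured step covers an ethynyl group, so the direction is open, and the expected step is a number 5 percentage points higher from compound 3 to compound 4 (within the scatter). Compound 4 is therefore estimated at 42%, with a range from 20% to 65%.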

Compound 4, a percentage reported as inhibition, in the whole organism at one dose (the size of the read-out at that dose, not a potency): 84.9%
Estimate against measurement, compound 4: 42.9 percentage points below; the measured number lies above the stated range.
By their numbers in this assay, from the lowest: compounds 1 and 3 (each within the scatter of the next); then compound 2; then compound 4.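

In this assay the ring on the amide-type nitrogen proves able to give more than the fluoro compound showed: ethynyl in place of hydrogen gives a number 50.7 percentage points higher from compound 1 to compound 4 (beyond the scatter) and sets compound 4 clear of both fluorine-bearing compounds, with a number 20.5 percentage points higher from compound 2 to compound 4 (beyond the scatter) and with a number 47.9 percentage points higher from compound 3 to compound 4 (beyond the scatter). Compound 4 therefore stands highest of the four, and the top number here comes from a group without fluorine. Nothing measured here accounts for this rise. The compounds shown leave open whether 4-ethynylphenyl would match 3-ethynylphenyl, and whether a nitrile or an amine on this ring would hold the number.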